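Moving the amine onto a cyclohexane ring in an aorta assay

A few compounds are considered here, and "the series" means these few. Any claim that something is new, unique, unknown or untested is made for them only; others in the source may bear on it.

Three compounds share one core and differ only in the group attached to the carbonyl carbon of the amide. Compound 1 `N[C@H](C(=O)Nc1cc2cc[nH]c(=O)c2cc1Cl)C1CCCCC1` carries a cyclohexyl group with the amine beside the carbonyl; in a functional assay (aorta) with Rattus norvegicus as the target (a higher number here means that more compound is needed for the effect, a lower number that less compound is needed), compound 1 gives 180 nM. As far as these compounds go, compound 2 `CC(C)C[C@H](N)C(=O)Nc1cc2cc[nH]c(=O)c2cc1Cl` carries the open-chain 1-amino-3-methylbutyl group instead, but in this assay compound 2 gives "not determined" (no result reported), so its standing on the numbers is unknown. Compound 3 `N[C@H]1CC[C@@H](C(=O)Nc2cc3cc[nH]c(=O)c3cc2Cl)CC1` has not yet been tested. It differs from compound 2 in one place: 4-aminocyclohexyl in place of 1-amino-3-methylbutyl on a carbonyl carbon. Among the measured compounds shown here, with no measured step between compounds of this kind on record, the size of the change in this assay cannot be read from any neighbouring pair. The cyclohexane-bearing compound 1 is the only anchor, and it shows that a ring-containing group in this position can be tolerated. Compound 3 is therefore estimated to land near the same range, with a broad spread in either direction, at 500 nM with a range from 100 nM to 3000 nM.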

Compound 3, half-maximal effective concentration: 180 nM
Beside the measured number, compound 3's estimate is 2.8-fold (0.44 log units) above it; low and high end bracket the measured number.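

Among the compounds shown here, compound 2 has no single number to set beside compound 3 in this assay, so no step between these two compounds can be read. The compounds shown leave open whether 4-aminocyclohexyl in place of 1-amino-3-methylbutyl changes the concentration needed for the effect. No supporting data here bear on this result.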